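Pyridin-2-yl in Place of Fluorophenyl on the Shared Core

A few compounds are considered here, and "the series" means these few. Any claim that something is new, unique, unknown or untested is made for them only; others in the source may bear on it.

Compound 1 `Nc1nc(N2CCN(C(=O)COc3ccc(Cl)cc3)CC2)c2nc(-c3ccc(F)cc3)sc2n1` carries a ((4-chlorophenoxy)methyl)carbonyl group on an amine nitrogen in a ring and a 4-fluorophenyl group on the fused five-membered ring. In a functional assay on cells (Lymphocyte, Homo sapiens) (on this read-out higher numbers stand for weaker inhibition and lower numbers for stronger inhibition), compound 1 gives 490 nM. Two measured neighbours differ from it in one place each. Compound 3 `COc1ccc(OCC(=O)N2CCN(c3nc(N)nc4sc(-c5ccc(F)cc5)nc34)CC2)cc1` has methoxy in place of chloro on an aromatic carbon; in this assay compound 3 gives 40 nM, and the step is a 12-fold lower number from compound 1 to compound 3 (1.09 log units; beyond the scatter). Compound 2 `Nc1nc(N2CCN(S(=O)(=O)c3ccccc3)CC2)c2nc(-c3ccc(F)cc3)sc2n1` has phenylsulfonyl in place of the carbonyl group on the amine nitrogen. For compound 2 the result in this assay is only a limit, > 10000 nM, which is the limit of > 10000 nM in this assay, at which 1 of the 3 values shown sits. The step there is an at least 20-fold higher number from compound 1 to compound 2 (1.30 log units; beyond the scatter). Among the numbers reported, compound 1 therefore stands highest, with compound 3 as its nearest neighbour.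

Compound 4 `Nc1nc(N2CCN(C(=O)COc3ccc(Cl)cc3)CC2)c2nc(-c3ccccn3)sc2n1` differs from compound 1 thus: pyridin-2-yl in place of 4-fluorophenyl on an aromatic carbon. Neither measured step touches this side of the shared core; both alter the group on the amine nitrogen in the ring. Within the data shown here, no measured step bears directly on the new change, so no shift beyond the scatter is expected in either direction. Compound 4 is estimated at 600 nM, within 150 nM to 2500 nM, which is expected to amount to a 1.2-fold higher number from compound 1 to compound 4 (0.09 log units; within the scatter).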

Compound 4, half-maximal inhibitory concentration: 230 nM
The estimate for compound 4 lay 2.6-fold (0.42 log units) above the measured number; the range from low to high includes it.
By their numbers in this assay, from the lowest: compound 3; then compound 4; then compound 1. At a limit, above all of these: compound 2.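

Among these compounds, the side of the shared core that the earlier steps left untouched also responds in this assay: with the group on the amine nitrogen unchanged, the change to pyridin-2-yl gives a 2.1-fold lower number from compound 1 to compound 4 (0.33 log units; beyond the scatter), a modest step but one beyond the scatter. This position on the five-membered aromatic ring therefore accepts a six-membered aromatic ring with 1 hetero atom and 1 hydrogen-bond acceptor in place of the carbon-only ring bearing fluorine, and inhibition is not lost but somewhat strengthened. Nothing measured here gives a reason for this shift.

The compounds shown do not separate the loss of the fluorine from the entry of the ring nitrogen, a question that a plain phenyl group or a pyridin-3-yl group on the same aromatic carbon would bear on. They also leave open whether pyridin-2-yl would have the same effect alongside the methoxy group of compound 3, or whether a saturated ring such as piperidine or a small group such as methyl would be accepted at this position.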